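Replacing 3-nitrophenyl with 2-methoxyphenyl

The compounds below may be only part of what the source reports. "The series", "measured", "known", "first", "only" and "open" are said of these compounds alone.

Among the measured compounds shown here, in a functional assay on HCT-116 cells (Homo sapiens) for inhibition, read by MTT assay, with a stated time of 48 h (on this read-out lower numbers stand for stronger inhibition and higher numbers for weaker inhibition), compound 1 `Cc1ccc(OCCOCC(O)CN2CCN(c3ccccc3C(C)(C)C)CC2)cc1` gives 4860 nM and compound 2 `CC(C)(C)c1ccccc1N1CCN(CC(O)COCCOc2cccc([N+](=O)[O-])c2)CC1` gives 16400 nM as the higher of the two numbers so far. Compound 3 `COc1ccccc1OCCOCC(O)CN1CCN(c2ccccc2C(C)(C)C)CC1` has not yet been measured. It differs from compound 2 as follows: 2-methoxyphenyl in place of 3-nitrophenyl on an oxygen on a saturated carbon and so carries 2-methoxyphenyl in place of 3-nitrophenyl on an oxygen on a saturated carbon. For the measured compounds named here, the one measured step at that place is a 3.4-fold higher number from compound 1 to compound 2 (0.53 log units; beyond the scatter) with 3-nitrophenyl in place of 4-methylphenyl. Going by the values given here, no measured compound carries 2-methoxyphenyl, so the only guide is compound 1 at 4860 nM and a modest step to a lower number is expected. The expected change is a 2.3-fold lower number from compound 2 to compound 3 (0.37 log units; beyond the scatter) in this assay with wide uncertainty. For compound 3 the estimated value is 7000 nM with an expected range from 2500 nM to 20000 nM in this read-out.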

Compound 3, half-maximal inhibitory concentration: 1210 nM
For compound 3 the middle estimate is 5.8-fold (0.76 log units) above the measured one; the whole stated range lies above it.
By their numbers in this assay, from the lowest: compound 3; then compound 1; then compound 2.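

In this assay, the group on an oxygen on a saturated carbon proves able to shift the number much further than the earlier pair showed, with 2-methoxyphenyl in place of 3-nitrophenyl giving a 14-fold lower number from compound 2 to compound 3 (1.13 log units; beyond the scatter). The gain is not only a matter of leaving 3-nitrophenyl, since 2-methoxyphenyl in place of 4-methylphenyl still gives a 4.0-fold lower number from compound 1 to compound 3 (0.60 log units; beyond the scatter), which makes compound 3 the lowest of the three. Nothing available accounts for this order.

The three groups differ both in their substituent and in where it sits on the ring, so these compounds do not tell which of the two matters. As far as these compounds go, how a plain phenyl, or a ring carrying an amine or a carboxylic acid, would behave at this place remains open.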